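This account rests on a few compounds, and the source may have more. Where it says the series, first, only, none or still open, it means among the compounds named here.

Measured in a functional assay on cells (Hepatocyte, Rattus norvegicus, strain Wistar), using NADPH; on this read-out lower numbers stand for stronger inhibition and higher numbers for weaker inhibition:
- Compound 1 `COC1=C(O)C(=O)O[C@@H]1[C@@H](O)CO`: 1000000 nM
- Compound 2 `O=C1OC(C(O)CO)C(OCCCCCCO[N+](=O)[O-])=C1O`: 80000 nM
- Compound 3 `O=C1OC(C(O)CO)C(OCCCCC(CO[N+](=O)[O-])O[N+](=O)[O-])=C1O`: 28000 nM

Compound 2 stands second highest of these three numbers. Compound 4 `O=C1OC(C(O)CO)C(OCCCO[N+](=O)[O-])=C1O` departs from it by nitrooxy in place of 3-(nitrooxy)propyl on a saturated chain carbon, three bonds along the chain from an oxygen on an unsaturated carbon. Among the compounds with values here, no measured step covers this change. The nearest guide is a 2.9-fold lower number from compound 2 to compound 3 (0.46 log units; beyond the scatter), a modest step beyond the scatter, but it reflects a different change and indicates size only. The direction is suggested by compound 1, which has no nitrooxy group and gives 1000000 nM. In this assay a similarly modest move towards a higher number is therefore expected, an estimated 2.1-fold higher number from compound 2 to compound 4 (0.33 log units; beyond the scatter). The estimated value for compound 4 is 170000 nM, within a range of 50000 nM to 500000 nM.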

Compound 4, half-maximal inhibitory concentration in the Hepatocyte assay: 454000 nM
For compound 4 the middle estimate is 2.7-fold (0.43 log units) below the measured one; the range from low to high includes it.
By their numbers in the Hepatocyte assay, from the lowest: compound 3; then compound 2; then compound 4; then compound 1.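

In the Hepatocyte assay, compound 2 gives 80000 nM and compound 4 gives 454000 nM; nitrooxy in place of 3-(nitrooxy)propyl gives a 5.7-fold higher number from compound 2 to compound 4 (0.75 log units; beyond the scatter), so the length of the chain carrying the nitrooxy group matters at this position, which the earlier step of a 2.9-fold lower number from compound 2 to compound 3 (0.46 log units; beyond the scatter), adding a second nitrooxy group, did not show. In a physicochemical assay for acid dissociation, compound 2 gives 7.6 and compound 4 gives 7.55; the same change gives a number 0.05 log units lower from compound 2 to compound 4 (within the scatter), so that read-out does not separate the two compounds. Nothing shown accounts for the shift in the cell read-out. On these data alone, what stays open is how a chain longer than that of compound 2, or a carboxylic acid or an amine in place of the terminal nitrooxy group, would read in the Hepatocyte assay.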